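Replacing a Methyl with a Phenyl on Compound 1

This account rests on a few compounds, and the source may have more. Where it says the series, first, only, none or still open, it means among the compounds named here.

Among the measured compounds shown here, in a functional assay on Raji cells (Homo sapiens) for cytotoxicity, read by CCK-8 assay, with a stated time of 24 h (on this read-out lower numbers stand for stronger inhibition and higher numbers for weaker inhibition), compound 1 (`C=CC(=O)N1C(=O)CC(c2ccc(C)cc2)Sc2ccccc21`) gives 75500 nM, the lower of the two numbers measured so far, while compound 2 (`C=CC(=O)N1C(=O)CC(c2cccs2)Sc2ccccc21`) gives 659000 nM. The next compound to be tested is compound 3 (`C=CC(=O)N1C(=O)CC(c2ccc(-c3ccccc3)cc2)Sc2ccccc21`). It keeps the core of compound 1 and differs by phenyl in place of methyl on an aromatic carbon, para to a large group.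

For the measured compounds named here, only one measured step bears on this change: an 8.7-fold higher number from compound 1 to compound 2 (0.94 log units; beyond the scatter). There, thiophen-2-yl replaces the whole 4-methylphenyl group, so the step shows that altering this group can move the number by a modest amount beyond the scatter. Going by the values given here, no measured step replaces the methyl alone, which leaves the direction open, and a swap of this kind could go either way. Among the compounds with values here, a change no larger than that step is the reasonable expectation, with a slight lean toward a lower number. The expected outcome is a 1.5-fold lower number from compound 1 to compound 3 (0.18 log units; within the scatter), which may not clear the usual scatter. For compound 3 the estimated value is 50000 nM, with an expected range from 12000 nM to 220000 nM.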

Compound 3, half-maximal inhibitory concentration: 56300 nM
Compound 3: middle estimate off by 1.1-fold (0.05 log units), on the low side, and the stated range covers the measured number.
By their numbers in this assay, from the lowest: compounds 3 and 1 (each within the scatter of the next); then compound 2.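

In this assay the swap gives a 1.3-fold lower number from compound 1 to compound 3 (0.13 log units; within the scatter) and so the two compounds cannot be told apart on this read-out. This is the first step among the compounds shown that replaces the methyl alone while leaving the rest of the 4-methylphenyl group in place. It shows that phenyl, with 6 heavy atoms and a ring of its own, can stand in place of methyl, with 1 heavy atom, on this aromatic carbon without moving the number beyond the scatter, and no measurement at hand explains why the number holds.

On these data alone, all the groups on this carbon so far carry carbon only, so it remains open whether an amine or a carboxylic acid here would leave the number where it is or shift it beyond the scatter. A longer chain, such as butyl, is equally untested among these compounds, and so the tolerance seen with phenyl cannot yet be stretched into a general rule for this position.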